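A furan swapped for phenyl at the assay limit

A few compounds are considered here, and "the series" means these few. Any claim that something is new, unique, unknown or untested is made for them only; others in the source may bear on it.

In a functional assay on HCT-116 cells (Homo sapiens), read by MTT assay, with a stated time of 72 h (on this read-out lower numbers stand for stronger inhibition and higher numbers for weaker inhibition), compound 1 `CNc1ncnc2c1c(-c1ccco1)cn2[C@@H]1O[C@H](CO)[C@@H](O)[C@H]1O` gives 230 nM. Compound 2 `Cc1nc(N)c2c(-c3ccoc3)cn([C@@H]3O[C@H](CO)[C@@H](O)[C@H]3O)c2n1` gives > 20000 nM, which is a limit of the assay and not a true number. These two compounds differ in more than one place, so their values say nothing about any single change. Compound 3 `Cc1nc(N)c2c(-c3ccccc3)cn([C@@H]3O[C@H](CO)[C@@H](O)[C@H]3O)c2n1` keeps the core of compound 2 and alters one group: phenyl in place of furan-3-yl on an aromatic carbon. Going by the values given here, no measured pair shows what this swap does in this assay, so the expectation rests on compound 2, whose reading of > 20000 nM is only a limit. At most a small strengthening is expected, and the estimated step is an at least 1.3-fold lower number from compound 2 to compound 3 (0.12 log units; that floor lies within the scatter). Compound 3 is estimated at 15000 nM, within an expected range from 4000 nM to 20000 nM.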

Compound 3, half-maximal inhibitory concentration: > 100000 nM
Compound 3 was reported as a limit; the forecaster's own chance of this, stated with the estimate: 70%; middle value at least 6.6-fold (0.82 log units) away from the limit.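

Compound 2 and compound 3 each sit at a limit of this assay, not at a true number, and no step can be read between them. The compounds shown leave open whether phenyl in place of furan-3-yl strengthens inhibition, weakens it or leaves it unchanged.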